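Swapping the ring on the sulfonyl group of compound 1

The source may report more compounds than this note shows. Statements on the series, on what has been measured and on what is new or still open speak of the compounds shown alone.

Compound 1 `O=S(=O)(c1cccc(-c2ccc3nccc(-c4ccncc4)c3n2)c1)N1CCC(O)CC1` was tested in an ADME assay on microsomes from liver (Rattus norvegicus) for metabolic stability, read by LC-MS, using NADPH, with a stated time of 30 min, tested at 0.1 uM (on this read-out lower numbers stand for a less stable compound and higher numbers for a more stable compound), and gave 11%. Of the three measured numbers that is the second highest, though compound 3 `O=S(=O)(NCc1ccccc1)c1cccc(Nc2ccc3nccc(-c4ccncc4)c3n2)c1` with 6% lies within the scatter of it, so the two cannot be told apart; only compound 2 `O=S(=O)(NCCO)c1cccc(Nc2ccc3nccc(-c4ccncc4)c3n2)c1` with 58% stands clearly higher. For the measured compounds named here, the one measured step, a number 52 percentage points lower from compound 2 to compound 3 (beyond the scatter), shows how much a change at the sulfonamide end can move this read-out. Compound 4 `C[C@@H]1CN(S(=O)(=O)c2cccc(-c3ccc4nccc(-c5ccncc5)c4n3)c2)C[C@H](C)N1` differs from compound 1 by 3,5-dimethylpiperazin-1-yl in place of 4-hydroxypiperidin-1-yl on a sulfonyl sulfur. Going by the values given here, no measured pair repeats this replacement of one saturated ring by another on the sulfonyl sulfur, and the step from compound 2 to compound 3 concerns a different group on a different atom, so it offers no direct guide. With nothing to point either way, compound 4 is expected to stay close to compound 1, with a number 4 percentage points higher from compound 1 to compound 4 (within the scatter) amounting to no step beyond the scatter, and its estimated value is 15% within a range of 3% to 40%.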

Compound 4, percent of the compound remaining: 36%
Compound 4: middle estimate off by 21 percentage points, on the low side, and the stated range covers the measured number.
By their numbers in this assay, from the lowest: compounds 3 and 1 (each within the scatter of the next); then compound 4; then compound 2.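

The saturated ring on the sulfonyl sulfur is not a neutral part of the molecule: in this assay the change from 4-hydroxypiperidin-1-yl to 3,5-dimethylpiperazin-1-yl gives a number 25 percentage points higher from compound 1 to compound 4 (beyond the scatter). For the compounds shown here, this is the first measured step at this place, and it shows that replacing one six-membered non-aromatic ring with another can move the read-out even when both groups count the same hydrogen-bond donors and acceptors. No measurement shown here accounts for the rise.

The change brings in a second ring nitrogen, two methyl groups and two defined stereocentres at once, and the compounds shown do not tell these apart. From the compounds shown here alone, it remains open whether a plain piperazin-1-yl ring, without the methyl groups, would give a number nearer compound 1 or compound 4.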